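The compounds below may be only part of what the source reports. "The series", "measured", "known", "first", "only" and "open" are said of these compounds alone.

Working notes on the series. Compound 1 `Cc1ccc(S(=O)(=O)NC(=O)Nc2ccccc2C(=O)/C=C/c2ccccc2)cc1` is measured in an ADME assay on the whole organism for cytotoxicity, with Artemia salina as the target, with a stated time of 24 h (on this read-out higher numbers stand for an effect only at larger amounts of compound and lower numbers for an effect already at smaller amounts), where compound 1 gives 25 ug/mL. The two hydroxy-bearing relatives are compound 2 `Cc1ccc(S(=O)(=O)NC(=O)Nc2ccccc2C(=O)/C=C/c2cccc(O)c2)cc1` and compound 3 `Cc1ccc(S(=O)(=O)NC(=O)Nc2ccccc2C(=O)/C=C/c2ccc(O)cc2)cc1`; in this assay compound 2 gives 39.3 ug/mL and compound 3 gives 24.3 ug/mL. All three numbers lie within the scatter of one another, so compound 1 sits neither apart from compound 3 nor from compound 2, and the steps among them are small: a 1.6-fold higher number from compound 1 to compound 2 (0.20 log units; within the scatter), a 1.0-fold lower number from compound 1 to compound 3 (0.01 log units; within the scatter), and a 1.6-fold lower number from compound 2 to compound 3 (0.21 log units; within the scatter).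

Compound 4 `CCOc1cc(/C=C/C(=O)c2ccccc2NC(=O)NS(=O)(=O)c2ccc(C)cc2)ccc1O` is not yet measured in this assay. Relative to compound 1 the difference is 3-ethoxy-4-hydroxyphenyl in place of phenyl on a double-bonded chain carbon bound to a double-bonded chain carbon. Going by the values given here, the steps that bear on it are the two hydroxy additions from compound 1, both within the scatter, and the shift between the two hydroxyphenyl isomers, also within the scatter. Among the compounds with values here, nothing among the measured steps suggests that decorating the aromatic ring on the double-bonded chain carbon moves the number beyond the scatter, although no ethoxy-bearing compound has been measured, so the added ethoxy remains untested. On that basis the step is expected to be a 1.1-fold higher number from compound 1 to compound 4 (0.05 log units; within the scatter), essentially flat. Compound 4 is therefore estimated at 28 ug/mL in this assay, with a range from 14 ug/mL to 56 ug/mL.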

Compound 4, concentration for half-maximal effect: 19.2 ug/mL
Beside the measured number, compound 4's estimate is 1.5-fold (0.16 log units) above it, and the stated range covers the measured number.
By their numbers in this assay, from the lowest: compounds 4, 3, 1 and 2 (each within the scatter of the next, the first and the last beyond it).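

In this assay, going by these compounds alone, the added ethoxy is now tested for the first time and gives a 1.3-fold lower number from compound 3 to compound 4 (0.10 log units; within the scatter), and the whole exchange of phenyl for 3-ethoxy-4-hydroxyphenyl on a double-bonded chain carbon bound to a double-bonded chain carbon gives a 1.3-fold lower number from compound 1 to compound 4 (0.11 log units; within the scatter), so this place takes the larger group without a readable shift from either compound. Within the data shown here, the one step to pass the scatter is a 2.0-fold lower number from compound 2 to compound 4 (0.31 log units; beyond the scatter), a modest separation that holds only for this pair and forms no trend across the series. Nothing available explains any of these steps.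

Still open is whether the ethoxy counts on its own, since in the compounds shown it always appears together with the hydroxy on the same ring. Also open, from the compounds shown here alone, is how this place responds to groups of another kind on that ring, such as an amine, a carboxylic acid or a longer chain such as butoxy in place of ethoxy.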